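From compound 3 to compound 4: replacing one bromine

This account rests on a few compounds, and the source may have more. Where it says the series, first, only, none or still open, it means among the compounds named here.

The series varies one group on the shared core. In a toxicity assay on MDCK cells (Canis lupus familiaris) for cytotoxicity, read by CCK-8 assay, with a stated time of 48 h (a lower number here means that less compound is tolerated, a higher number that more compound is tolerated), compound 1 (`COc1ccc(C(=O)NNc2c(Br)cccc2Br)cc1`) gives > 100000 nM, which is a limit of the assay. Within the data shown here, compound 2 (`COC(=O)c1ccc(C(=O)NNc2c(Br)cccc2Br)cc1`) gives 87600 nM, the only actual number so far. Compound 3 (`O=C(NNc1c(Br)cccc1Br)c1ccc(Br)cc1`) gives > 100000 nM, again a limit, so its position is known only as a limit. Reading of the measured steps is bounded by the limit of > 100000 nM in this assay, at which 2 of the 3 values shown sit.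

Compound 4 (`O=C(NNc1c(Br)cccc1Br)c1ccc(B(O)O)cc1`) differs from compound 3 as follows: a group of 3 heavy atoms (1 boron, 2 oxygen; no ring) in place of one bromine atom, on an aromatic carbon. The change lies on an aromatic carbon, para to a large group.

Among the measured compounds shown here, three measured steps touch this carbon. The first is an at least 1.1-fold lower number from compound 1 to compound 2 (0.05 log units; that floor lies within the scatter), the second is an at least 1.1-fold higher number from compound 2 to compound 3 (0.05 log units; that floor lies within the scatter), and both are floors within the scatter. The third is a step that the two limits leave unreadable from compound 1 to compound 3, which cannot be sized. None of them shows a step beyond the scatter, though the limits hide any true size.

In this assay, no step beyond the scatter is therefore expected, and the estimate is an at least 1.1-fold lower number from compound 3 to compound 4 (0.04 log units; that floor lies within the scatter). A number close to that of compound 2 at 87600 nM is the likeliest reading. Compound 4 is estimated at 90000 nM, with an expected range of 40000 nM to 200000 nM.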

Compound 4, half-maximal cytotoxic concentration: > 100000 nM
Compound 4 ended at the assay's limit (the forecaster's own chance of this, stated with the estimate: 50%); at least 1.1-fold (0.04 log units) between middle value and limit.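

In this assay compound 4 gives > 100000 nM, which is a limit of the assay, so placing a group with 2 hydrogen-bond donors and 2 hydrogen-bond acceptors on this aromatic carbon, in place of a bromo group with 0 of each, produces no readable fall in the number. Among these compounds, the only step with a readable floor is an at least 1.1-fold higher number from compound 2 to compound 4 (0.05 log units; that floor lies within the scatter), so this result does not separate compound 2 from compound 4. The steps to compound 4 from compound 1 and from compound 3 cannot be read, and methoxy, bromo and the new group of 3 heavy atoms (1 boron, 2 oxygen; no ring) now all stand at one bound on the reading of this position: the limit of > 100000 nM in this assay, at which 3 of the 4 values shown sit.

As far as these compounds go, the true separation among compound 1, compound 3 and compound 4 remains open, as does whether any group at this position can move the number beyond the scatter. From the compounds shown here alone, how an amine, a carboxylic acid or a longer chain on this aromatic carbon would read in this assay also remains open.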